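A few compounds are considered here, and "the series" means these few. Any claim that something is new, unique, unknown or untested is made for them only; others in the source may bear on it.

Measured in an ADME assay on NIH3T3 cells (Mus musculus) for cytotoxicity, with a stated time of 72 h; on this read-out lower numbers stand for stronger inhibition and higher numbers for weaker inhibition:
- Compound 1 `OC[C@H]1O[C@@H](n2cnc3c(NCc4ccccc4F)ncnc32)[C@H](O)[C@@H]1O`: > 166000 nM, a limit of the assay
- Compound 2 `COc1ccccc1CNc1ncnc2c1ncn2[C@@H]1O[C@H](CO)[C@@H](O)[C@H]1O`: 140000 nM
- Compound 3 `OC[C@H]1O[C@@H](n2cnc3c(NCc4ccc(F)c(F)c4F)ncnc32)[C@H](O)[C@@H]1O`: "not determined" (no result reported)

Among the compounds with values here, compound 3 has no number in this assay, so no step from it can be sized. Going to compound 4 `OC[C@H]1O[C@@H](n2cnc3c(NCc4ccc(F)cc4Cl)ncnc32)[C@H](O)[C@@H]1O` puts 2-chloro-4-fluorophenyl in place of 2,3,4-trifluorophenyl (2-chloro-4-fluorophenyl in place of 2,3,4-trifluorophenyl on a saturated chain carbon bound to a nitrogen on an aromatic ring). Within the data shown here, the only measured step bearing on this is a different change on the same kind of group, methoxy in place of fluoro: an at least 1.1-fold lower number from compound 1 to compound 2 (0.07 log units; that floor lies within the scatter). Its floor lies within the scatter. No step beyond the scatter is therefore expected in this assay relative to the two measured compounds, though this rests on one step. For compound 4 the expected value is 130000 nM, estimated to lie between 60000 nM and 250000 nM.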

Compound 4, half-maximal inhibitory concentration: > 166000 nM
Compound 4: a limit, no number; the forecaster's own chance of this, stated with the estimate: 45%; middle value at least 1.2-fold (0.10 log units) away from the limit.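

In this assay compound 4 sits at a limit, > 166000 nM, so 2-chloro-4-fluorophenyl, the only chlorine-bearing group shown at this position, also gives no number. Within the data shown here, the one readable step is an at least 1.1-fold higher number from compound 2 to compound 4 (0.07 log units; that floor lies within the scatter); the other steps to compound 4 cannot be read. Much of what this position shows is therefore bounded by a single ceiling: the limit of > 166000 nM in this assay, at which 2 of the 4 values shown sit.

As far as these compounds go, whether an amine or a carboxylic acid in place of these phenyl groups would give a clearly lower number stays open. So does how 2,3,4-trifluorophenyl in compound 3 compares.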